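The compounds below may be only part of what the source reports. "The series", "measured", "known", "first", "only" and "open" are said of these compounds alone.

Measured so far:
compound 1 `COc1cc(Cl)cc(-c2nn(-c3cccc(NC(=O)Nc4ccc(Cl)c(C(F)(F)F)c4)c3)cc2-c2ccncc2)c1`, 37%;
compound 2 `COc1cc(Cl)cc(-c2nn(-c3cccc(NC(=O)Nc4cc(C(F)(F)F)cc(C(F)(F)F)c4)c3)cc2-c2ccncc2)c1`, 5%;
compound 3 `COc1cc(Cl)cc(-c2nn(-c3cccc(NC(=O)Nc4ccc(Cl)c(Cl)c4)c3)cc2-c2ccncc2)c1`, 82%.

In a functional assay on CCRF-CEM cells (Homo sapiens) for inhibition, read by sulforhodamine B assay, with a stated time of 48 h, tested at 1 uM (on this read-out higher numbers stand for a weaker effect at the one concentration tested and lower numbers for a stronger effect), compound 3 stands highest of the three numbers, with compound 1 nearest and compound 2 furthest, both beyond the scatter. Compound 4 `COc1cc(Cl)cc(-c2nn(-c3cccc(NC(=O)Nc4cccc(C(F)(F)F)c4)c3)cc2-c2ccncc2)c1` differs from compound 3 by 3-(trifluoromethyl)phenyl in place of 3,4-dichlorophenyl on an amide-type nitrogen. Going by the values given here, the one measured step that bears on this is a number 45 percentage points higher from compound 1 to compound 3 (beyond the scatter), where chloro in place of trifluoromethyl raised the number strongly; the change from compound 3 to compound 4 runs the other way, trifluoromethyl arriving as chloro leaves. Compound 4 is therefore expected to show a number 37 percentage points lower from compound 3 to compound 4 (beyond the scatter), a step downward in this assay beyond the scatter. Compound 4 is estimated at 45%, within 15% to 80%.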

Compound 4, a percentage reported as activity, at one concentration (the size of the read-out at that concentration, not a potency): 56%
The estimate for compound 4 lay 11 percentage points below the measured number; the range from low to high includes it.
By their numbers in this assay, from the lowest: compound 2; then compound 1; then compound 4; then compound 3.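

With 3-(trifluoromethyl)phenyl alone on the amide-type nitrogen, this assay now shows what a second group on that ring adds: replacing a trifluoromethyl by hydrogen gives a number 51 percentage points higher from compound 2 to compound 4 (beyond the scatter), and replacing a chloro by hydrogen gives a number 19 percentage points higher from compound 1 to compound 4 (beyond the scatter). Both added groups thus go with a stronger effect, yet 3,4-dichlorophenyl is weaker than the singly substituted ring, with a number 26 percentage points lower from compound 3 to compound 4 (beyond the scatter). No measurement shown explains these shifts. On these data alone, whether a nitrile or a methoxy group as that second group would also strengthen the effect remains open.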